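Working notes: side-chain swap from compound 3 to compound 4

The source may report more compounds than this note shows. Statements on the series, on what has been measured and on what is new or still open speak of the compounds shown alone.

Measured in an ADME assay on L6 cells (Rattus norvegicus) for cytotoxicity, read by fluorescence, with a stated time of 72 h; on this read-out higher numbers stand for weaker inhibition and lower numbers for stronger inhibition:
- compound 1 `CCN(CC)C(=O)CNC1CC2(N3CCN(C)CC3)CC(c3ccccc3)C1C(c1ccccc1)C2`: 37900 nM
- compound 2 `CN1CCN(C23CC(NC(=O)CN4CCCC4)C(C(c4ccccc4)C2)C(c2ccccc2)C3)CC1`: 27800 nM
- compound 3 `CN1CCN(C23CC(NC(=O)CN4CCCCC4)C(C(c4ccccc4)C2)C(c2ccccc2)C3)CC1`: 22100 nM

Compound 3 stands within the scatter of both other compounds, with a 1.7-fold lower number from compound 1 to compound 3 (0.23 log units; within the scatter) and a 1.3-fold lower number from compound 2 to compound 3 (0.10 log units; within the scatter).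

The next compound is compound 4 `CCN(CC)CCC(=O)NC1CC2(N3CCN(C)CC3)CC(c3ccccc3)C1C(c1ccccc1)C2`. It carries (diethylamino)methyl in place of piperidin-1-yl on a saturated chain carbon bound to a carbonyl carbon.

Among the compounds with values here, three measured steps bear on this change. The closest is the exchange of pyrrolidin-1-yl for piperidin-1-yl at the same place, which gave a 1.3-fold lower number from compound 2 to compound 3 (0.10 log units; within the scatter). The two steps away from the (diethylcarbamoyl)methyl group of compound 1 gave a 1.4-fold lower number from compound 1 to compound 2 (0.13 log units; within the scatter) and a 1.7-fold lower number from compound 1 to compound 3 (0.23 log units; within the scatter). No side-chain change among these compounds has yet gone beyond the scatter, although none of them is the same exchange as the one now in question.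

No step beyond the scatter is therefore expected in this assay. The expected step is a 1.2-fold higher number from compound 3 to compound 4 (0.09 log units; within the scatter). Compound 4 is estimated at 27000 nM, with an expected range from 14000 nM to 50000 nM.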

Compound 4, half-maximal inhibitory concentration: 35900 nM
Beside the measured number, compound 4's estimate is 1.3-fold (0.12 log units) below it; measured number inside the range.
By their numbers in this assay, from the lowest: compounds 3, 2, 4 and 1 (each within the scatter of the next).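

In this assay, a side chain with no ring, at the place on a saturated chain carbon bound to a carbonyl carbon, stays within the scatter of both ring-bearing side chains (a 1.6-fold higher number from compound 3 to compound 4 (0.21 log units; within the scatter); a 1.3-fold higher number from compound 2 to compound 4 (0.11 log units; within the scatter)). The (2-(diethylamino)ethyl)carbonyl group on an amine nitrogen likewise stays within the scatter of the (diethylcarbamoyl)methyl group (a 1.1-fold lower number from compound 1 to compound 4 (0.02 log units; within the scatter)), so among these four compounds the side chains with a ring do not stand apart from those without one. Nothing measured here bears on why these steps are small.

The step from (piperidin-1-yl)methyl to 2-(diethylamino)ethyl changes both the ring and the chain, and a (2-(piperidin-1-yl)ethyl)carbonyl group would separate the two. From the compounds shown here alone, whether a carboxylic acid or a morpholin-4-yl group at this place would step beyond the scatter remains open.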